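From a Hydroxyhexyl Amine to an Aminobutoxy Side Chain

The source may hold more compounds than are shown below. What is called first, only, known or untested is meant among the compounds shown, and "the series" means these compounds.

Of the compounds shown here, two built on a shared core have been measured so far in a functional assay on MCF7 cells (Homo sapiens) for inhibition, read by fluorescence, with a stated time of 72 h; a higher number here means a weaker inhibitor, a lower number a stronger inhibitor. Compound 1 `CCCn1cnc2c(NC(=N)N)nc(N)nc21` gives 36500 nM, while compound 2 `CC(C)n1cnc2c(NC(=N)N)nc(NCCCCCCO)nc21` gives 5200 nM. Compound 2 therefore holds the lower number of the two and is the stronger inhibitor, and the gap between them lies beyond the usual scatter of repeat measurements. These two compounds differ in more than one place, so their gap cannot be tied to any single change.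

Compound 3 `CC[C@H](N)COc1nc(NC(=N)N)c2ncn(C(C)C)c2n1` has not yet been measured. It carries 2-aminobutoxy in place of (6-hydroxyhexyl)amino on an aromatic carbon, between two ring nitrogen atoms: 2-aminobutoxy in place of (6-hydroxyhexyl)amino on an aromatic carbon. The starting point is compound 2 at 5200 nM. Among the measured compounds shown here, no pair of measured compounds isolates this swap, so the range has to stay wide. The expected change, a 1.3-fold higher number from compound 2 to compound 3 (0.13 log units; within the scatter), is slightly towards weaker inhibition and stays within the scatter. For compound 3 the estimated value is 7000 nM, with an expected range of 2000 nM to 25000 nM.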

Compound 3, half-maximal inhibitory concentration: 16300 nM
Compound 3: middle estimate off by 2.3-fold (0.37 log units), on the low side, within the range that was stated.
By their numbers in this assay, from the lowest: compound 2; then compound 3; then compound 1.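

In this assay, among the compounds shown here, putting 2-aminobutoxy in place of (6-hydroxyhexyl)amino on this aromatic carbon, between two ring nitrogen atoms, gives a 3.1-fold higher number from compound 2 to compound 3 (0.50 log units; beyond the scatter), a modest step towards weaker inhibition that is the first change at a single place in this set, and it shows that the group at this position can shift the number beyond the scatter. The swap still bundles several differences: the group that enters is shorter, is joined through oxygen rather than nitrogen, ends differently, and has one defined stereocentre. Nothing shown here explains the step.

What remains open is which of these differences accounts for the weaker inhibition, since a single step cannot pull them apart. A 6-hydroxyhexyloxy chain would test the oxygen link while keeping the longer chain and its terminal hydroxyl, whereas a 2-aminobutylamino group would keep the shorter amine-bearing chain while restoring the nitrogen link, and the mirror-image form of 2-aminobutoxy would address the stereocentre.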